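The source may report more compounds than this note shows. Statements on the series, on what has been measured and on what is new or still open speak of the compounds shown alone.

Two compounds of the series carry a number in a functional assay on Hep 3B2 cells (Homo sapiens) for cytotoxicity, read by MTT assay, with a stated time of 72 h; a lower number here means a stronger inhibitor, a higher number a weaker inhibitor. Compound 1 `CC/C(=C\c1cc(OC)c(OC)c(OC)c1)C(=O)N1CCC=C(Cl)C1=O` gives 19000 nM in this assay. Within the data shown here, compound 2 `CC/C(=C\c1cc(OC)c(OC)c(OC)c1)C(=O)N1CCC=C(Br)C1=O` gives 8120 nM in this assay, and the step of a 2.3-fold lower number from compound 1 to compound 2 (0.37 log units; beyond the scatter) is the only measured step in the set. Among the measured compounds shown here, on the numbers so far compound 2 stands lowest of the two, with compound 1 as its sole neighbour at a higher number, that gap lying beyond the scatter.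

Compound 3 `COc1cc(/C=C(\C)C(=O)N2CCC=C(Br)C2=O)cc(OC)c1OC` differs from compound 2 in one place: hydrogen in place of methyl on a saturated chain carbon bound to a double-bonded chain carbon. For the measured compounds named here, no measured step bears on this change. Going by the values given here, the single step in the set puts bromo in place of chloro on a double-bonded ring carbon and carries no information on ethyl to methyl. The expectation therefore rests on compound 2 alone, and the step of a 1.0-fold higher number from compound 2 to compound 3 (0.02 log units; within the scatter) is expected to stay within the scatter, its direction undecided. For compound 3 the estimate in this assay is 8500 nM, with a range from 3000 nM to 24000 nM, the width reflecting the absence of any bearing step.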

Compound 3, half-maximal inhibitory concentration: 3100 nM
Estimate against measurement, compound 3: 2.7-fold (0.44 log units) above; the measured number falls inside the stated range.
By their numbers in this assay, from the lowest: compound 3; then compound 2; then compound 1.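

In this assay the chain on the double-bonded chain carbon proves able to move the number: ethyl to methyl gives a 2.6-fold lower number from compound 2 to compound 3 (0.42 log units; beyond the scatter) and so shortens the chain by one carbon with a lower number as the result. The earlier compounds shown here showed only a change on the double-bonded ring carbon, bromo in place of chloro, with a 2.3-fold lower number from compound 1 to compound 2 (0.37 log units; beyond the scatter), so the core of compound 2 now has a second place where a single change lies beyond the scatter, and both steps run towards a lower number. Nothing measured here accounts for the effect of the shorter chain.

The compounds shown leave open whether the trend continues to a bare hydrogen in place of the methyl of compound 3, and how a longer chain such as propyl, or a chain ending in an amine or a carboxylic acid, would read in this assay at this place. They also leave open whether ethyl to methyl gives a step of similar size with chloro rather than bromo on the double-bonded ring carbon.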